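From a long branched chain to phenyl

A few compounds are considered here, and "the series" means these few. Any claim that something is new, unique, unknown or untested is made for them only; others in the source may bear on it.

Measured in a functional assay (Nicotiana tabacum); a lower number here means a stronger inhibitor, a higher number a weaker inhibitor:
- compound 1 `CNc1nc(SC)nc2ncccc12` gives 2920 nM
- compound 2 `CCCNc1nc(SC)nc2ncccc12` gives 270 nM
- compound 3 `CCCCC(CC)CNc1nc(SC)nc2ncccc12` gives 15900 nM

Compound 3 (15900 nM) has the highest number of the three and is the weakest inhibitor measured. Compound 4 `CSc1nc(NCc2ccccc2)c2cccnc2n1` carries phenyl in place of 1-ethylpentyl on a saturated chain carbon bound to a nitrogen on an aromatic ring. Three chain steps bear on this change and they run both ways: an 11-fold lower number from compound 1 to compound 2 (1.03 log units; beyond the scatter), then a 59-fold higher number from compound 2 to compound 3 (1.77 log units; beyond the scatter) and a 5.4-fold higher number from compound 1 to compound 3 (0.74 log units; beyond the scatter). Among the measured compounds shown here, no compound with a ring at this place has been measured, so the guidance is indirect. Since both other compounds lie well below compound 3, a large step is expected in this assay, estimated as an 11-fold lower number from compound 3 to compound 4 (1.03 log units; beyond the scatter). For compound 4 the estimated value is 1500 nM with an expected range from 250 nM to 9000 nM in this assay.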

Compound 4, half-maximal inhibitory concentration: 25200 nM
Compound 4: middle estimate off by 17-fold (1.23 log units), on the low side; measured number above the stated range.
By their numbers in this assay, from the lowest: compound 2; then compound 1; then compounds 3 and 4 (each within the scatter of the next).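

In this assay phenyl in place of 1-ethylpentyl gives a 1.6-fold higher number from compound 3 to compound 4 (0.20 log units; within the scatter) so the long branched chain and the aromatic ring cannot be told apart at this place. Phenyl differs clearly from ethyl (a 93-fold higher number from compound 2 to compound 4 (1.97 log units; beyond the scatter)) and from hydrogen (an 8.6-fold higher number from compound 1 to compound 4 (0.94 log units; beyond the scatter)) so compound 2 keeps the lowest number of the four, and a ring at this place does not reach it. From the compounds shown here alone, whether cyclohexyl or an unbranched butyl chain would stand nearer to ethyl or to phenyl remains open. No measured evidence accounts for this result.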